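The compounds below may be only part of what the source reports. "The series", "measured", "known", "first", "only" and "open" are said of these compounds alone.

Measured in a functional assay on PC-3 cells (Homo sapiens) for antiproliferative activity, read by WST assay, with a stated time of 72 h; on this read-out higher numbers stand for an effect only at larger amounts of compound and lower numbers for an effect already at smaller amounts:
- compound 1 `CCCCCCCC/C=C\c1c(C)nc(C)c(/C=C\CCCCCCCC)c1C`: > 30 uM
- compound 2 `CCCCCCCCCCc1c(C)cc(C)[n+]2c1CCC2`: 0.9 uM
- compound 3 `CCCCCCCC/C=C/c1c(C)c(/C=C/CCCCCCCC)c2[n+](c1C)CCC2`: 0.6 uM

The entry for compound 1 is a limit of the assay, not a number.

Among the compounds with values here, compound 2 at 0.9 uM and compound 3 at 0.6 uM lie within the usual scatter of each other, and these are the only two numbers available. Compound 4 `CCCCCCCC/C=C\c1c(C)c(/C=C/CCCCCCCC)c2[n+](c1C)CCC2` is the next to consider, and its relation to compound 3 is simple: the two compounds have the same atoms and bonds and differ only in configuration as drawn: 1 of 2 stereo elements differ; a double bond is drawn E in compound 3 and Z in compound 4. Within the data shown here, no measured pair shows what such a change does, so no shift beyond the scatter is expected in this assay. The expected step is a 1.2-fold higher number from compound 3 to compound 4 (0.07 log units; within the scatter). For compound 4 the estimated value is 0.7 uM, with an expected range from 0.25 uM to 2.5 uM.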

Compound 4, concentration for half-maximal effect: 0.5 uM
The estimate for compound 4 lay 1.4-fold (0.15 log units) above the measured number, and the stated range covers the measured number.
By their numbers in this assay, from the lowest: compounds 4, 3 and 2 (each within the scatter of the next). At a limit, above all of these: compound 1.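

This pair is the first among the compounds shown that isolates the drawing of one double bond as E or Z, and in this assay the change barely registers: a 1.2-fold lower number from compound 3 to compound 4 (0.08 log units; within the scatter). At this position, then, switching the double bond from E to Z leaves the number within the usual scatter, and no other structural change clouds the reading: the fact that compounds 3 and 4 differ only in the configuration as drawn

From the compounds shown here alone, whether drawing the second double bond Z as well would behave the same way stays open. So does the effect of a shorter chain, or of a chain carrying an amine or a carboxylic acid, in place of these chains.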